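Heptyl to Isopropylamino: Expected Effect on Cytotoxicity

The source may report more compounds than this note shows. Statements on the series, on what has been measured and on what is new or still open speak of the compounds shown alone.

Measured so far:
compound 1, `Cc1cc(C(=O)Nc2ccc3nc(NC(=O)C4CCCCC4)sc3c2)c(C)n1C`: > 6.2 ug/mL
compound 2, `CCCCCCCC(=O)Nc1nc2ccc(NC(=O)c3c(Cl)cccc3Cl)cc2s1`: 0.18 ug/mL

Of the compounds shown here, two have been tested in a functional assay on WI-38 VA13 cells (Homo sapiens) for cytotoxicity; a higher number here means that more compound is needed for the effect, a lower number that less compound is needed. Compound 1 `Cc1cc(C(=O)Nc2ccc3nc(NC(=O)C4CCCCC4)sc3c2)c(C)n1C` returned > 6.2 ug/mL, which is a limit of the assay and not a number. Compound 1 is the one that sits at the limit of > 6.2 ug/mL in this assay, at which 1 of the 2 values shown sits. Compound 2 `CCCCCCCC(=O)Nc1nc2ccc(NC(=O)c3c(Cl)cccc3Cl)cc2s1` gave 0.18 ug/mL in this assay. Among the measured compounds shown here, compound 2 thus holds the only number; the other value is a limit, so no step between measured compounds can be sized.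

Compound 3 `CC(C)NC(=O)Nc1nc2ccc(NC(=O)c3c(Cl)cccc3Cl)cc2s1` is the unmeasured analogue of compound 2. The change is isopropylamino in place of heptyl on a carbonyl carbon, that is, isopropylamino enters where heptyl left, on the carbonyl carbon whose other neighbour is an amide-type nitrogen; cut one bond further out, the heptylcarbonyl becomes an isopropylcarbamoyl.

For the measured compounds named here, with no measured step to lean on, the expectation rests on compound 2 alone. The step from compound 2 to compound 3 in this assay is estimated as a 5.6-fold higher number from compound 2 to compound 3 (0.74 log units; beyond the scatter), a moderate rise beyond the scatter. Compound 3 is expected to give about 1 ug/mL in this assay, within a range from 0.3 ug/mL to 4 ug/mL.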

Compound 3, half-maximal effective concentration: 0.03 ug/mL
For compound 3 the middle estimate is 33-fold (1.52 log units) above the measured one; the measured number lies below the stated range.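

In this assay, among the compounds shown here, isopropylamino in place of heptyl on a carbonyl carbon gives a 6.0-fold lower number from compound 2 to compound 3 (0.78 log units; beyond the scatter), the first sized step at this position, which compound 2 on its own could not provide. It shows that the heptyl chain is not needed to keep the effect in this assay: once the heptylcarbonyl becomes an isopropylcarbamoyl, less compound is needed, not more. For the compounds shown here, nothing measured here accounts for the step, and the single change replaces the carbon chain and brings in a nitrogen together, so the two cannot be told apart.

The compounds shown leave open whether a plain isopropyl on the same carbonyl carbon would give a similar value without the nitrogen, and whether heptylamino would do so with the nitrogen but the longer chain. They also leave open how far this position stretches beyond these groups, for instance to a cyclohexylamino group or to a short chain ending in a carboxylic acid or an amine.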